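Tolerance in liver cells: from compound 3 to compound 4

The source may hold more compounds than are shown below. What is called first, only, known or untested is meant among the compounds shown, and "the series" means these compounds.

Compound 1, `CN1CCN(CCCNCc2cn(-c3ccc(C(F)(F)F)cc3)nc2-c2ccc(OC(F)(F)F)cc2)CC1`: 2300 nM
Compound 2, `Cc1ccc(-c2nn(-c3ccc(F)cc3F)cc2CNCCN2CCN(C)CC2)cc1`: > 20000 nM
Compound 3, `COc1ccc(-n2cc(CNCCN3CCN(C)CC3)c(-c3ccccc3C)n2)cc1`: > 20000 nM

Of the compounds shown here, three have been measured in an ADME assay on Huh-7 cells (Homo sapiens) for cytotoxicity; a higher number here means that more compound is tolerated, a lower number that less compound is tolerated. Compound 1 gives 2300 nM. For compound 2 the value > 20000 nM is a limit of the assay, not a number. For compound 3 the value > 20000 nM is likewise a limit of the assay. For the measured compounds named here, compound 3 therefore stands at the limit of > 20000 nM in this assay, at which 2 of the 3 values shown sit, together with compound 2, while compound 1 is the only compound of the three with a number. Compound 4, `Cc1ccccc1-c1nn(-c2ccccc2Cl)cc1CNCCN1CCN(C)CC1`, has not yet been measured in this assay. It differs from compound 3 in one place: 2-chlorophenyl in place of 4-methoxyphenyl on an aromatic nitrogen. Going by the values given here, no measured pair in the set differs in one place, so there is no measured step on which to rest an expectation; the shared core and the remaining groups are unchanged between compound 3 and compound 4. The analyst expects compound 4 to sit again at or near the limit, and estimates the step of a number no higher from compound 3 to compound 4 (the limit leaves the size open) as none beyond the scatter. The estimate for compound 4 is 20000 nM, within 8000 nM to 40000 nM, with a good chance that this assay returns only a limit.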

Compound 4, half-maximal cytotoxic concentration: > 20000 nM
Compound 4: no number, only a limit; the forecaster's own chance of this, stated with the estimate: 65%; the middle value sits exactly at the limit.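

In this assay compound 4 gives > 20000 nM, which is a limit of the assay and not a number. Compound 3 also gives only a limit, so no step between compound 3 and compound 4 can be read: the limit of > 20000 nM in this assay, at which 3 of the 4 values shown sit.

The compounds shown leave open how much of compound 3 or compound 4 the cells tolerate, and whether 2-chlorophenyl in place of 4-methoxyphenyl changes that tolerance at all.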